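From dibromohydroxyphenyl to dihydroxyphenyl: what to expect

The compounds below may be only part of what the source reports. "The series", "measured", "known", "first", "only" and "open" are said of these compounds alone.

Compound 1 `COc1cc2ncnc(Nc3ccc(F)c(Cl)c3)c2cc1NC(=O)N/N=C/c1ccc(F)cc1` gives 26600 nM
Compound 2 `COc1cc2ncnc(Nc3ccc(F)c(Cl)c3)c2cc1NC(=O)N/N=C/c1cc(Br)c(O)c(Br)c1` gives 34600 nM

Both numbers come from a functional assay on A549 cells (Homo sapiens) for cytotoxicity, read by MTT assay, with a stated time of 72 h (on this read-out higher numbers stand for weaker inhibition and lower numbers for stronger inhibition), and both compounds share one core, differing only in the ring on the far end of the chain. Among the compounds with values here, compound 2 stands level with compound 1, the only other compound measured so far, since repeated measurements of this kind naturally vary by about this much. The next compound is compound 3 `COc1cc2ncnc(Nc3ccc(F)c(Cl)c3)c2cc1NC(=O)N/N=C/c1ccc(O)cc1O` and its change is 2,4-dihydroxyphenyl in place of 3,5-dibromo-4-hydroxyphenyl on a carbon with a double bond to nitrogen with 2,4-dihydroxyphenyl in place of 3,5-dibromo-4-hydroxyphenyl on a carbon with a double bond to nitrogen.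

Within the data shown here, one measured step bears on this. It exchanged 4-fluorophenyl for 3,5-dibromo-4-hydroxyphenyl at that same place and gave a 1.3-fold higher number from compound 1 to compound 2 (0.11 log units; within the scatter) as its result. Two compounds are thin evidence, but going by that step of compound 2, no shift beyond the scatter is expected in this assay and no direction can be favoured. The estimated step is a 1.2-fold lower number from compound 2 to compound 3 (0.09 log units; within the scatter) and so stays small. For compound 3 the estimated value is 28000 nM with an expected range from 11000 nM to 70000 nM as its span.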

Compound 3, half-maximal inhibitory concentration: 31400 nM
For compound 3 the middle estimate is 1.1-fold (0.05 log units) below the measured one; low and high end bracket the measured number.
By their numbers in this assay, from the lowest: compounds 1, 3 and 2 (each within the scatter of the next).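

In this assay the exchange at the carbon with a double bond to nitrogen gives a 1.1-fold lower number from compound 2 to compound 3 (0.04 log units; within the scatter) and the exchange of 4-fluorophenyl for the same 2,4-dihydroxyphenyl gives a 1.2-fold higher number from compound 1 to compound 3 (0.07 log units; within the scatter) in this series. A third ring now stands at this place, and the numbers of all three compounds remain level with one another, whether the ring carries a fluorine, two bromines with a hydroxyl, or two hydroxyls, so among these three rings the choice does not show up in this read-out. Nothing at hand gives a reason for this flat result.

Going by these compounds, all three compounds still carry a substituted phenyl ring at this place, so it remains open whether an amine, a carboxylic acid or a longer chain there would move the number beyond the scatter. On these data alone, the three compounds also share one core, and what a change in that core would do to the number in this assay stays unknown.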